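Benzyl ring swap carried from an aniline pair to an acrylamide

This account rests on a few compounds, and the source may have more. Where it says the series, first, only, none or still open, it means among the compounds named here.

Compound 1 `Nc1ccc(/C=C2\SC(=O)N(Cc3cccc(Cl)c3)C2=O)cc1` and compound 2 `C=C(Br)C(=O)Nc1cccc(/C=C2\SC(=O)N(Cc3cccc(Cl)c3)C2=O)c1` share a core whose difference is not broken down here. Going by the values given here, in a functional assay on HeLa cells (Homo sapiens) for cytotoxicity, read by cell counting, with a stated time of 4 days (on this read-out higher numbers stand for weaker inhibition and lower numbers for stronger inhibition), compound 1 gives 24000 nM, and compound 2 gives 2500 nM, the lowest of the three numbers measured so far. Compound 3 `Nc1ccc(/C=C2\SC(=O)N(Cc3ccc(F)cc3)C2=O)cc1` carries the change 4-fluorophenyl in place of 3-chlorophenyl on a saturated chain carbon bound to an amide-type nitrogen in a ring against compound 1, and in this assay compound 3 gives 186000 nM; that step is a 7.8-fold higher number from compound 1 to compound 3 (0.89 log units; beyond the scatter). Compound 4 `C=C(Br)C(=O)Nc1cccc(/C=C2\SC(=O)N(Cc3ccc(F)cc3)C2=O)c1` carries the same change against compound 2, namely (4-fluorophenyl in place of 3-chlorophenyl on a saturated chain carbon bound to an amide-type nitrogen in a ring), and the place of the change matches word for word. Whether the acrylamide-bearing core of compound 2 responds in the same direction as the aniline-bearing core of compound 1 is not known from any measured pair, so the expectation rests on a single step. Among the compounds with values here, compound 4 is expected to give 18000 nM in this assay, within 6000 nM to 55000 nM, because the step of a 7.8-fold higher number from compound 1 to compound 3 (0.89 log units; beyond the scatter) is the only guide; the expected step is a 7.2-fold higher number from compound 2 to compound 4 (0.86 log units; beyond the scatter).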

Compound 4, half-maximal inhibitory concentration: 800 nM
For compound 4 the middle estimate is 23-fold (1.35 log units) above the measured one, and the stated range ends above it.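

In this assay, the change from 3-chlorobenzyl to 4-fluorobenzyl gives a 3.1-fold lower number from compound 2 to compound 4 (0.49 log units; beyond the scatter), so on this core it lowers the number rather than raising it. In this series, a step measured on one core therefore does not carry to the other in either direction or size: the same change on two cores in this assay, a 7.8-fold higher number (0.89 log units; beyond the scatter) from compound 1 to compound 3 and a 3.1-fold lower number (0.49 log units; beyond the scatter) from compound 2 to compound 4, 24-fold (1.38 log units) apart, beyond the scatter of two such steps

This shows that the effect of the change depends on the core it sits on, but with one pair per core it does not show which part of the difference between the two cores goes with the reversal, nor how other benzyl groups would behave. It also gives no reason for the reversal.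

The compounds shown leave open whether the reversal follows the bromine-bearing acrylamide itself, which a plain acetamide on the same core would help to separate. They also leave open whether an unsubstituted benzyl would follow the 3-chlorobenzyl or the 4-fluorobenzyl on each core.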